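The source may report more compounds than this note shows. Statements on the series, on what has been measured and on what is new or still open speak of the compounds shown alone.

Measured compounds:
compound 1, `CCCCCCCCCCCCc1ccc(-c2c(C)[nH]c(=O)n2C)cc1`, 13000 nM
compound 2, `CCCCCCCCCCCCCCc1ccc(-c2c(C)[nH]c(=O)n2C)cc1`, 43800 nM
compound 3, `CCCCCCCCOc1ccc(-c2c(C)[nH]c(=O)n2C2CCCCC2)cc1`, 8500 nM

All three were tested in a functional assay on brain (Rattus norvegicus, strain Wistar) for inhibition; on this read-out higher numbers stand for weaker inhibition and lower numbers for stronger inhibition. Compound 1 and compound 2 share one core and differ only at the far end of the long chain: ethyl in place of hydrogen on a saturated chain carbon, ten or more bonds along the chain from an aromatic carbon. That single change gave a 3.4-fold higher number from compound 1 to compound 2 (0.53 log units; beyond the scatter), so the longer chain went together with weaker inhibition in this assay.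

Compound 3 carries a different core; how the two cores differ is not broken down here. In this assay, among the measured compounds shown here, compound 3 gives 8500 nM, a number within the scatter of the one for compound 1 and well apart from the one for compound 2.

Compound 4, `CCCCCCCCCCOc1ccc(-c2c(C)[nH]c(=O)n2C2CCCCC2)cc1`, is not yet measured. It comes from compound 3 by ethyl in place of hydrogen on a saturated chain carbon, eight bonds along the chain from an oxygen on an aromatic ring. For the measured compounds named here, this is the same kind of change as the one from compound 1 to compound 2, though the surroundings differ: there the ethyl entered on a chain attached to an aromatic carbon, here on a chain attached to an oxygen on an aromatic ring, and the distance along the chain is not the same.

Going by the values given here, because the only comparable example is a 3.4-fold higher number from compound 1 to compound 2 (0.53 log units; beyond the scatter), the step to compound 4 is expected to be a 2.4-fold higher number from compound 3 to compound 4 (0.37 log units; beyond the scatter), a weakening of similar order. Compound 4 is therefore estimated at 20000 nM, most likely between 8000 nM and 55000 nM.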

Compound 4, half-maximal inhibitory concentration: 10500 nM
Estimate against measurement, compound 4: 1.9-fold (0.28 log units) above; the range from low to high includes it.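

In this assay, putting ethyl in place of hydrogen on the chain of compound 3 gave a 1.2-fold higher number from compound 3 to compound 4 (0.09 log units; within the scatter) and so cannot be told apart from no effect on this core. The same change had a clearer effect on the other core, so in this series its size does not carry over unchanged from one core to the other, and the gap between the two steps is larger than repeat measurements alone would be expected to produce: the same change on two cores in this assay, a 3.4-fold higher number (0.53 log units; beyond the scatter) from compound 1 to compound 2 and a 1.2-fold higher number (0.09 log units; within the scatter) from compound 3 to compound 4, 2.7-fold (0.44 log units) apart, beyond the scatter of two such steps. This does not show why the steps differ, since the two pairs differ both in the core and in how the chain is attached, one directly to an aromatic carbon and the other through an oxygen on an aromatic ring, and two pairs cannot separate those differences or establish a general rule.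

The compounds shown leave open whether a longer chain on the core of compound 3 would bring a clear weakening like the one seen on the core of compound 1. They also leave open how either core would respond to a shorter chain, or to a chain ending in an amine or a carboxylic acid.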